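A few compounds are considered here, and "the series" means these few. Any claim that something is new, unique, unknown or untested is made for them only; others in the source may bear on it.

In a functional assay on the whole organism with Rattus norvegicus as the target (a higher number here means that more compound is needed for the effect, a lower number that less compound is needed), compound 1 (`N=c1sc2cc(OC(F)(F)F)ccc2n1CCS(N)(=O)=O`) gives 6 mg/kg as its dose. Compound 2 (`N=c1sc2cc(OC(F)(F)F)ccc2n1CCS(=O)(=O)O`) gives > 10 mg/kg as a limit and not a number, so it stands at the limit of > 10 mg/kg in this assay, at which 1 of the 2 values shown sits, and has no exact place. Compound 3 (`N=c1sc2cc(OC(F)(F)F)ccc2n1CCO`) carries hydroxy in place of sulfo on a saturated chain carbon, two bonds along the chain from an aromatic nitrogen. Within the data shown here, with an at least 1.6-fold higher number from compound 1 to compound 2 (0.22 log units; that floor lies within the scatter) as the only measured guide, a different swap at the sulfonyl sulfur, a small move to a lower number is expected, and an at least 1.4-fold lower number from compound 2 to compound 3 (0.15 log units; that floor lies within the scatter) is the estimated step. Compound 3 is expected near 7 mg/kg with 2.5 mg/kg to 20 mg/kg as the estimated range.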

Compound 3, dose for half-maximal effect: 8 mg/kg
Beside the measured number, compound 3's estimate is 1.1-fold (0.06 log units) below it; low and high end bracket the measured number.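

With hydroxy in place of sulfo on this chain, the result is an at least 1.2-fold lower number from compound 2 to compound 3 (0.09 log units; that floor lies within the scatter), a floor set by a limit and not a full step. Compound 2 is held only by a limit and not by a number: the limit of > 10 mg/kg in this assay, at which 1 of the 3 values shown sits.

With hydroxy in place of sulfamoyl, the result is a 1.3-fold higher number from compound 1 to compound 3 (0.12 log units; within the scatter), so among these compounds a sulfur group at this place is not needed for a measurable dose in this assay.

Going by these compounds, what a carboxylic acid or an amine at the end of the chain would do stays open, as does the effect of a longer chain carrying the hydroxy. On these data alone, the exact dose of compound 2 also stays open.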